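The source may hold more compounds than are shown below. What is called first, only, known or untested is meant among the compounds shown, and "the series" means these compounds.

Two compounds share a core in which an imidazoline-bearing aniline is linked through a methylene to an alkoxyphenyl ring. Compound 1 `CCOc1ccc(Cc2ccc(NC3=NCCN3)cc2)cc1` carries an ethoxy group and, in a functional assay on SH-SY5Y cells (Homo sapiens) for antagonist activity, read by cAMP accumulation (a higher number here means a more potent compound, by a factor of ten per unit of this negative logarithm, a lower number a less potent compound), compound 1 gives 8.2. Compound 2 `CCCOc1ccc(Cc2ccc(NC3=NCCN3)cc2)cc1` extends this to propoxy, and in this assay compound 2 gives 8.8. Among the measured compounds shown here, the only measured step is a number 0.60 log units higher from compound 1 to compound 2 (beyond the scatter), so compound 2 stands at the higher of the two numbers.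

Compound 3 `CC(C)Oc1ccc(Cc2ccc(NC3=NCCN3)cc2)cc1` differs from compound 2 by isopropyl in place of propyl on an oxygen on an aromatic ring. For the measured compounds named here, no measured step involves a branched chain, so the gain seen in a number 0.60 log units higher from compound 1 to compound 2 (beyond the scatter) cannot be carried over directly; the change keeps the same atoms and merely rearranges them. Compound 3 is therefore expected to land close to compound 2, with a step of a number 0.20 log units lower from compound 2 to compound 3 (within the scatter) that may well stay within the scatter. The estimate for compound 3 in this assay is 8.6, with a range from 8 to 9.2.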

Compound 3, negative logarithm of the antagonist equilibrium constant: 8.8
Compound 3: the middle estimate sits 0.20 log units below what was measured; measured number inside the range.
By their numbers in this assay, from the lowest: compound 1; then compounds 2 and 3 (each within the scatter of the next).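

In this assay, moving from the straight chain to the branched one on the oxygen on an aromatic ring leaves the number in place, with no change at the digits printed from compound 2 to compound 3 (within the scatter), so at this position isopropyl serves as well as propyl. The branched ether also keeps the gain over ethoxy, with a number 0.60 log units higher from compound 1 to compound 3 (beyond the scatter), which means that in these three compounds the extra carbon counts the same whether it lengthens the chain or branches it. Nothing available explains why the rearranged chain makes no difference.

As far as these compounds go, it remains open whether a longer chain such as butoxy, or a ring such as cyclopentyloxy on the same oxygen, would hold this level or move away from it. Where the shorter methoxy would stand is equally open.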